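From Nitrile to Carboxy on the Amide Side Chain

The source may report more compounds than this note shows. Statements on the series, on what has been measured and on what is new or still open speak of the compounds shown alone.

In a functional assay on PC-3 cells (Homo sapiens), read by MTT assay, with a stated time of 48 h (a lower number here means a stronger inhibitor, a higher number a weaker inhibitor), compound 3 `CCn1c(C(=O)N(C)CCC#N)ccc1C(CC)(CC)c1ccc(OCC(O)C(C)(C)C)c(C)c1` gives 1700 nM and compound 2 `CCn1c(C(=O)NCCCN(C)C)ccc1C(CC)(CC)c1ccc(OCC(O)C(C)(C)C)c(C)c1` gives 3100 nM in the same range, as a 1.8-fold lower number from compound 2 to compound 3 (0.26 log units; within the scatter) shows. Compound 1 `CCOC(=O)CN(C)C(=O)c1ccc(C(CC)(CC)c2ccc(OCC(O)C(C)(C)C)c(C)c2)n1CC` stands well apart from both at 25500 nM and an 8.2-fold lower number from compound 1 to compound 2 (0.92 log units; beyond the scatter) marks its gap to compound 2.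

Compound 4 `CCn1c(C(=O)N(C)CC(=O)O)ccc1C(CC)(CC)c1ccc(OCC(O)C(C)(C)C)c(C)c1` differs from compound 3 by one change: carboxy in place of cyanomethyl on a saturated chain carbon bound to an amide-type nitrogen that is, carboxy in place of cyanomethyl on a saturated chain carbon bound to an amide-type nitrogen. The most relevant measurement is a 15-fold lower number from compound 1 to compound 3 (1.18 log units; beyond the scatter) for it involves this same place, where compound 1 carries ethoxycarbonyl. For the measured compounds named here, no measured compound carries carboxy, so the data cannot say how closely it will follow ethoxycarbonyl. Part of that large gap is expected to return in this assay on moving away from cyanomethyl. The expected change is a 4.1-fold higher number from compound 3 to compound 4 (0.61 log units; beyond the scatter) in the direction of a weaker inhibitor. For compound 4 the estimate is 7000 nM with 1800 nM to 30000 nM as the expected range.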

Compound 4, half-maximal inhibitory concentration: 23900 nM
The estimate for compound 4 lay 3.4-fold (0.53 log units) below the measured number; low and high end bracket the measured number.
By their numbers in this assay, from the lowest: compounds 3 and 2 (each within the scatter of the next); then compounds 4 and 1 (each within the scatter of the next).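

In this assay, carboxy in place of cyanomethyl on a saturated chain carbon bound to an amide-type nitrogen gives a large loss (a 14-fold higher number from compound 3 to compound 4 (1.15 log units; beyond the scatter)), so this position does respond to the group it carries. Compound 4 also sits well apart from the amine-bearing compound 2 (a 7.7-fold higher number from compound 2 to compound 4 (0.89 log units; beyond the scatter)), while replacing the ethyl of the ester with hydrogen leaves the reading within the scatter (a 1.1-fold lower number from compound 1 to compound 4 (0.03 log units; within the scatter)), so the free acid and the ethyl ester cannot be told apart here. No measurement shown accounts for this result.

The 2-cyanoethyl chain of compound 3 and the carboxymethyl chain of compound 4 differ in both their end group and their length. The compounds shown therefore leave open whether the gap follows the nitrile or the chain, a question that a 2-carboxyethyl group at this position would address.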